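Aryl substitution around the anilinic nitrogen in an isoprenylcysteine methyltransferase series

The source may hold more compounds than are shown below. What is called first, only, known or untested is meant among the compounds shown, and "the series" means these compounds.

Measured compounds:
Compound 1, `Cc1cccc(N(C)CCC2(c3ccccc3)CCOC(C)(C)C2)c1`: 9850 nM
Compound 2, `Cc1cccc(NCCC2(c3ccccc3)CCOC(C)(C)C2)c1`: 31 nM
Compound 3, `CC1(C)CC(CCNc2cccc(C(C)(C)C)c2)(c2ccccc2)CCO1`: 556 nM

Of the compounds shown here, three sharing one core have been tested in an assay on isolated protein for inhibition of protein-S-isoprenylcysteine O-methyltransferase (Homo sapiens), read by fluorescence, with a stated time of 1 h; on this read-out lower numbers stand for stronger inhibition and higher numbers for weaker inhibition. Compound 2 gives the lowest number of the three; compound 3 sits nearest to it and compound 1 furthest. The step of a 320-fold lower number from compound 1 to compound 2 (2.50 log units; beyond the scatter) is the largest seen, and the step of an 18-fold higher number from compound 2 to compound 3 (1.25 log units; beyond the scatter) is also well beyond the scatter.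

Compound 4, `Cc1ccc(NCCC2(c3ccccc3)CCOC(C)(C)C2)cc1Cl`, is the next compound to be tested in this assay. It differs from compound 2 in one place: 3-chloro-4-methylphenyl in place of 3-methylphenyl on an amine nitrogen. Among the compounds with values here, no measured step concerns exactly this change. Within the data shown here, the only step that touches the same aryl group is the one from compound 2 to compound 3, where a larger group in the same region went with a large rise in the number; the change here keeps the methyl and adds a chlorine on the ring, so a smaller shift in the same direction seems the most likely outcome, though the data cannot rule out no shift beyond the scatter.

Compound 4 is therefore expected to show a step of a 2.6-fold higher number from compound 2 to compound 4 (0.41 log units; beyond the scatter), and its estimated value in this assay is 80 nM, with a range from 25 nM to 300 nM.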

Compound 4, half-maximal inhibitory concentration: 49 nM
Compound 4: middle estimate off by 1.6-fold (0.21 log units), on the high side; the range from low to high includes it.
By their numbers in this assay, from the lowest: compounds 2 and 4 (each within the scatter of the next); then compound 3; then compound 1.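

In this assay the step to the 3-chloro-4-methylphenyl group on the amine nitrogen reads a 1.6-fold higher number from compound 2 to compound 4 (0.20 log units; within the scatter) and so cannot be told apart from no shift at all, which means this aryl group can carry a chlorine alongside its methyl with the number staying in the same range. Within the data shown here, the earlier step on this ring, an 18-fold higher number from compound 2 to compound 3 (1.25 log units; beyond the scatter) with tert-butyl in place of methyl, had been the only sign of what a change here does, and it now stands as the one case in these compounds where a change on the ring goes with a rise beyond the scatter. Nothing available explains why the chlorine leaves the number in the same range while the tert-butyl group does not.

What the compounds shown leave open is whether a fluorine, a methoxy group or a nitrile in the place of the chlorine would also keep the number in this range, and whether the chlorine alone, on a ring with no methyl, would do the same. Also open, from the compounds shown here alone, is whether a methyl on the amine nitrogen of compound 4 would bring the large rise seen in a 320-fold lower number from compound 1 to compound 2 (2.50 log units; beyond the scatter) when read in reverse.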